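Swapping the urea-side aryl group on a pyrimidine urea

The source may hold more compounds than are shown below. What is called first, only, known or untested is meant among the compounds shown, and "the series" means these compounds.

Measured so far:
Compound 1, `COc1cc(NC(=O)Nc2cc(Nc3cccc(C(C)(C)C)c3)ncn2)cc(OC)c1`: 68%
Compound 2, `COc1cc(Br)ccc1Nc1cc(NC(=O)Nc2c(Cl)cccc2Cl)ncn1`: 90.5%
Compound 3, `COc1cc(NC(=O)Nc2cc(Nc3ccc(Br)cc3OC)ncn2)cc(OC)c1`: 83%

Three compounds share one core and were tested in a functional assay on PC-9 cells (Homo sapiens) for inhibition, read by MTT assay, with a stated time of 48 h, tested at 10 uM; a lower number here means less inhibition, a higher number more inhibition at the concentration tested (going by the name of the read-out). In this assay compound 1 gives 68% and stands lowest of the three. Compound 3 differs from compound 1 only at the nitrogen on the aromatic ring, where (3-(tert-butyl)phenyl in place of 4-bromo-2-methoxyphenyl on a nitrogen on an aromatic ring); this change gave a number 15 percentage points higher from compound 1 to compound 3 (beyond the scatter). Compound 2 differs from compound 3 at the amide-type nitrogen, where (2,6-dichlorophenyl in place of 3,5-dimethoxyphenyl on an amide-type nitrogen); the step was a number 7.5 percentage points higher from compound 3 to compound 2 (within the scatter).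

Compound 4, `CC(C)(C)c1cccc(Nc2cc(NC(=O)Nc3c(Cl)cccc3Cl)ncn2)c1`, has not yet been measured in this assay. It is made from compound 1 by the same change that turned compound 3 into compound 2: 2,6-dichlorophenyl in place of 3,5-dimethoxyphenyl on an amide-type nitrogen. The place of the change is the same in both pairs, an amide-type nitrogen whose other neighbour is a carbonyl carbon, so the change is the same, only set on a different partner at the ring nitrogen.

Compound 4 is expected to come out at about 75%, with a plausible range from 60% to 90%. Going by the values given here, this means an expected step of a number 7 percentage points higher from compound 1 to compound 4 (within the scatter), which is taken as small because a number 7.5 percentage points higher from compound 3 to compound 2 (within the scatter) was the only time this change was seen, and it stayed within the usual scatter. Whether a change seen once carries over to a different partner at the ring nitrogen cannot be judged from three compounds alone.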

Compound 4, a percentage reported as inhibition, at one concentration (the size of the read-out at that concentration, not a potency): 87.1%
The estimate for compound 4 lay 12.1 percentage points below the measured number; measured number inside the range.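

In this assay, putting 2,6-dichlorophenyl in place of 3,5-dimethoxyphenyl on the amide-type nitrogen gave a number 19.1 percentage points higher from compound 1 to compound 4 (beyond the scatter). Going by these compounds alone, the same change has now been seen with two different partners at the ring nitrogen, and both steps point the same way, with no difference between them that can be told from the usual spread of such numbers: the same change on two cores in this assay, a number 7.5 percentage points higher (within the scatter) from compound 3 to compound 2 and a number 19.1 percentage points higher (beyond the scatter) from compound 1 to compound 4, 11.6 percentage points apart, within the scatter of two such steps This shows that, for these two pairs, the change carried from one core to the other, but two pairs make no general rule, only one of the steps lies beyond the scatter, and the size of the step on any further core cannot be predicted from them.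

The compounds shown compare only two groups on the amide-type nitrogen, so it stays open whether a phenyl ring with a single chlorine, a ring carrying an amine or a carboxylic acid, or a longer alkyl chain would fit the same picture. Each number also comes from one concentration, so these results describe the size of the inhibition at that concentration and leave the potency of the compounds open.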